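Adding a Chloro to the Strongest Nitrobenzyl Compound

The source may hold more compounds than are shown below. What is called first, only, known or untested is meant among the compounds shown, and "the series" means these compounds.

Compounds 1, 2 and 3 share one core and differ only at the edges. Compound 3 `O=[N+]([O-])c1ccccc1CNc1cc(C(F)(F)F)cc2[nH]ncc12` carries a nitrobenzyl group on an amine and a free aromatic nitrogen; in an assay for inhibition of Indoleamine 2,3-dioxygenase 1 (Homo sapiens), with stated times of 10 min and 60 min, tested at 100 uM (on this read-out lower numbers stand for a weaker effect and higher numbers for a stronger effect at the one concentration tested), compound 3 gives 76%. Compound 2 `O=[N+]([O-])c1ccc(CNc2cc(C(F)(F)F)cc3[nH]ncc23)cc1`, whose nitro group sits elsewhere on the benzyl ring, gives 61%, and compound 1 `NCCn1ncc2c(NCc3ccccc3[N+](=O)[O-])cc(C(F)(F)F)cc21`, which carries a 2-aminoethyl chain on the aromatic nitrogen, gives 30%. Compound 3 therefore stands highest of the three, and its gaps to compound 2 and to compound 1 both lie beyond the scatter. Among the compounds with values here, the one step measured between single-change neighbours is a number 46 percentage points higher from compound 1 to compound 3 (beyond the scatter).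

Compound 4 `O=[N+]([O-])c1ccc(Cl)cc1CNc1cc(C(F)(F)F)cc2[nH]ncc12` is the next compound, and it differs from compound 3 by chloro in place of hydrogen on an aromatic carbon. Within the data shown here, no measured step touches this kind of change: the only step available concerns the aromatic nitrogen of the core, not the benzyl ring, so it gives no guide to the size or direction of the effect of a chloro. With compound 3 already near the top of the scale, the step is expected to stay within the scatter, a number 4 percentage points lower from compound 3 to compound 4 (within the scatter). Compound 4 is therefore estimated at 72%, with a range from 50% to 90%.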

Compound 4, a percentage reported as inhibition, at one concentration (the size of the read-out at that concentration, not a potency): 65%
For compound 4 the middle estimate is 7 percentage points above the measured one; the measured number falls inside the stated range.
By their numbers in this assay, from the lowest: compound 1; then compounds 2 and 4 (each within the scatter of the next); then compound 3.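

The chloro enters on an aromatic carbon of the benzyl ring, para to a nitro group and meta to a large group, and in this assay this one change gives a number 11 percentage points lower from compound 3 to compound 4 (beyond the scatter). Within the data shown here, this is the first measured step on the benzyl ring rather than on the aromatic nitrogen of the core, and it shows that the read-out responds to a change at this carbon, though only modestly: compound 4 still gives 65% at the one concentration tested. Nothing available explains the lower number for the chloro compound.

A fluoro, a methyl or a methoxy group on the same carbon would show whether this step belongs to chloro alone or to any group placed there. On these data alone, it also remains open whether a chloro on another carbon of the benzyl ring would give a step of similar size and direction, and whether the step seen here would hold up in a measure of potency rather than of the effect at one concentration.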